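The source may report more compounds than this note shows. Statements on the series, on what has been measured and on what is new or still open speak of the compounds shown alone.

Of the compounds shown here, two from this series have been measured in a functional assay on cells (Cancer cell lines, Homo sapiens) for cytotoxicity, read by sulforhodamine B assay, with a stated time of 48 h; on this read-out lower numbers stand for stronger inhibition of growth and higher numbers for weaker inhibition of growth. Compound 1, with the structure `COc1ccc(C2=NN(C3=NC(=O)/C(=C4\C(=O)Nc5ccc(Br)cc54)S3)C(c3ccc(OC)cc3)C2)cc1`, gives 32500 nM in this assay. Compound 2, with the structure `COc1ccc(C2=NN(C3=NC(=O)/C(=C4\C(=O)Nc5ccccc54)S3)C(c3ccc(Cl)cc3)C2)cc1`, gives 100000 nM in this assay. Of these two numbers, compound 2 stands at the higher one, and its nearest neighbour is compound 1, whose number lies beyond the usual scatter below it. Among the compounds with values here, the two compounds differ in more than one place, so their values show only that compound 2 is the weaker of the pair, not which part of the structure accounts for the gap.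

Compound 3, with the structure `COc1ccc(C2=NN(C3=NC(=O)/C(=C4\C(=O)Nc5ccc(Br)cc54)S3)C(c3ccc(Cl)cc3)C2)cc1`, has not yet been measured. Compared with compound 2, it carries bromo in place of hydrogen on an aromatic carbon. The only hint at the outcome comes from compound 1, which also carries a bromo substituent on the same ring and shows 32500 nM, but that comparison is clouded by the second difference between compounds 1 and 2. The change is expected to give a modest step, a 2.0-fold lower number from compound 2 to compound 3 (0.30 log units; within the scatter), towards a lower number. Compound 3 is therefore estimated at 50000 nM, with a range from 15000 nM to 100000 nM.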

Compound 3, concentration for total growth inhibition: 14700 nM
Compound 3: middle estimate off by 3.4-fold (0.53 log units), on the high side; the measured number lies below the stated range.
By their numbers in this assay, from the lowest: compound 3; then compound 1; then compound 2.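

In this assay the swap of bromo in place of hydrogen, on an aromatic carbon of the six-membered ring that is part of the fused system of two rings, gives a 6.8-fold lower number from compound 2 to compound 3 (0.83 log units; beyond the scatter) and so shows, with only this one place changed, that this position responds to the substituent it carries. Compound 3 also links compound 1 and compound 2, which differ in two places: chloro in place of methoxy on an aromatic carbon gives a 2.2-fold lower number from compound 1 to compound 3 (0.34 log units; beyond the scatter) so the earlier gap now resolves into two single changes that both lead to stronger growth inhibition, leaving compound 3 the strongest of the three. Nothing measured here bears on why either change moves the number.

On these data alone, each step has been read only once and against one background, so it remains open whether bromo would give a similar step in a compound carrying methoxy instead of chloro. The compounds shown also leave open what fluoro, an amine or a carboxylic acid would do at the bromo position.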